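Methoxy pattern on the styryl ring in a benzyl vinyl sulfone series

A few compounds are considered here, and "the series" means these few. Any claim that something is new, unique, unknown or untested is made for them only; others in the source may bear on it.

Measured compounds:
compound 1 `COc1ccc(CS(=O)(=O)/C=C/c2ccc(OC)c(OC)c2)cc1`: > 20000 nM
compound 2 `COc1ccc(CS(=O)(=O)/C=C/c2cc(OC)cc(OC)c2)cc1`: > 20000 nM

Two analogues have been tested in a functional assay on DLD-1 cells (Homo sapiens) for antiproliferative activity, read by trypan blue exclusion; a lower number here means a stronger inhibitor, a higher number a weaker inhibitor. Compound 1 reaches only the limit of the assay, giving > 20000 nM. Compound 2 likewise returns only a limit, > 20000 nM. Neither is a number; both sit at the limit of > 20000 nM in this assay, at which 2 of the 2 values shown sit, so no order between compound 1 and compound 2 can be read, and compound 2 stands where every value shown stands, at the limit.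

Compound 3 `COc1ccc(CS(=O)(=O)/C=C/c2cc(OC)c(OC)c(OC)c2)cc1` is the next member. It differs from compound 2 by methoxy in place of hydrogen on an aromatic carbon. Within the data shown here, no measured step exists for this change, and nothing in the two limits shows how far a third methoxy might move the number. The expected step from compound 2 to compound 3 in this assay is an at least 10-fold lower number from compound 2 to compound 3 (1.00 log units; beyond the scatter), taken toward stronger inhibition, because a limit is all that compound 2 offers in this assay, namely > 20000 nM, and the first measurable number is anticipated here. For compound 3 the estimate is 2000 nM, with a range from 200 nM to 20000 nM.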

Compound 3, half-maximal inhibitory concentration: > 20000 nM
Compound 3 gave a limit, no number (the forecaster's own chance of this, stated with the estimate: 35%); middle value at least 10-fold (1.00 log units) away from the limit.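

Among these compounds, no step to compound 3 can be read from compound 1 or compound 2, as all three return only a limit and no number in this assay: the limit of > 20000 nM in this assay, at which 3 of the 3 values shown sit.

Still open, as far as these compounds go, is whether any methoxy pattern on the styryl ring gives a measurable number in this assay and how far an added methoxy moves it.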